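Chain length in a series of ureate transporter inhibitors

The source may hold more compounds than are shown below. What is called first, only, known or untested is meant among the compounds shown, and "the series" means these compounds.

Measured compounds:
- compound 1 `N#Cc1ccc(Oc2cnccc2SCCCCC(=O)O)c2ccccc12`: 4220 nM
- compound 2 `CN(c1cnccc1SCCCC(=O)O)c1ccc(C#N)c2ccccc12`: 2580 nM

In an assay on HEK293 cells for inhibition of solute carrier family 22 member 12 (Homo sapiens), read by scintillation counting, with stated times of 30 min and 15 min (a lower number here means a stronger inhibitor, a higher number a weaker inhibitor), compound 1 gives 4220 nM, the highest of the two numbers shown. Compound 2 gives 2580 nM in this assay, and its gap to compound 1 lies within the scatter, so no order between them can be read. Compound 3 `N#Cc1ccc(Oc2cnccc2SCCCC(=O)O)c2ccccc12` is not yet measured. It differs from compound 1 by carboxy in place of carboxymethyl on a saturated chain carbon, three bonds along the chain from a sulfur. Among the compounds with values here, no step between measured compounds shares this change, so nothing sets its size. The step from compound 1 to compound 3 is expected to be small, a 1.2-fold lower number from compound 1 to compound 3 (0.08 log units; within the scatter), not beyond the scatter. Compound 3 is expected to give 3500 nM, within 1500 nM to 8500 nM in this assay.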

Compound 3, half-maximal inhibitory concentration: 1230 nM
Compound 3: middle estimate off by 2.8-fold (0.45 log units), on the high side, and the stated range ends above it.
By their numbers in this assay, from the lowest: compound 3; then compounds 2 and 1 (each within the scatter of the next).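

In this assay, within the data shown here, going from 4-carboxybutyl to 3-carboxypropyl gives a 3.4-fold lower number from compound 1 to compound 3 (0.54 log units; beyond the scatter), the first step that can be read. Chain length at this position therefore matters on its own, and the shorter chain is the stronger inhibitor of this pair. Nothing available explains the size of this step.

The compounds shown leave open whether the number keeps falling with a 2-carboxyethyl chain or rises again. They also leave open whether a primary amide or a tetrazole could stand in for the carboxylic acid on the 3-carboxypropyl chain.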